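The source may report more compounds than this note shows. Statements on the series, on what has been measured and on what is new or still open speak of the compounds shown alone.

Three compounds share one core and differ only in the amine carried on a saturated chain carbon bound to an aromatic carbon. Compound 1 `CCN(CC)Cc1cc2c(N)nc(-c3ccco3)nc2s1` gives 2130 nM in an assay on CHO-K1 cells for antagonist activity at adenosine receptor A1 (Homo sapiens), read by a beta-galactosidase reporter, with stated times of 15 min and 6 h; on this read-out lower numbers stand for stronger inhibition and higher numbers for weaker inhibition. Compound 2 `Nc1nc(-c2ccco2)nc2sc(CN3CCC(F)CC3)cc12` gives 740 nM in this assay, and compound 3 `Nc1nc(-c2ccco2)nc2sc(CN3CCC(=O)CC3)cc12` gives 2720 nM in this assay. Compound 3 thus carries the highest number of the three; its gap to compound 1 is within the scatter, whereas the step of a 3.7-fold higher number from compound 2 to compound 3 (0.57 log units; beyond the scatter) lies beyond it. The steps of a 2.9-fold lower number from compound 1 to compound 2 (0.46 log units; beyond the scatter) and a 1.3-fold higher number from compound 1 to compound 3 (0.11 log units; within the scatter) show the spread that swaps at this one place have produced so far.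

Compound 4 `Nc1nc(-c2ccco2)nc2sc(CN3CC=CC3)cc12` is not yet measured. Relative to compound 3 the change is a group of 5 heavy atoms (4 carbon, 1 nitrogen; one five-membered non-aromatic ring with 1 hetero atom) in place of a group of 7 heavy atoms (5 carbon, 1 nitrogen, 1 oxygen; one six-membered non-aromatic ring with 1 hetero atom), on a saturated chain carbon bound to an aromatic carbon. All three measured steps bear on it, since each exchanges the amine at the same place, and none went beyond a modest size. The 4-oxopiperidin-1-yl group goes with the highest number of the set, and both other amines sat lower, so a modest move to a lower number in this assay is expected, staying inside the spread already seen. The step expected is a 2.1-fold lower number from compound 3 to compound 4 (0.32 log units; beyond the scatter). Compound 4 is expected at 1300 nM, with a range from 450 nM to 3800 nM.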

Compound 4, inhibition constant: 290 nM
For compound 4 the middle estimate is 4.5-fold (0.65 log units) above the measured one; measured number outside the range, below it.
By their numbers in this assay, from the lowest: compound 4; then compound 2; then compounds 1 and 3 (each within the scatter of the next).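

Going by these compounds alone, at this saturated chain carbon bound to an aromatic carbon, compound 4 carries the lowest number of the set in this assay, and its steps from all three earlier compounds lie beyond the scatter (a 9.4-fold lower number from compound 3 to compound 4 (0.97 log units; beyond the scatter); a 7.3-fold lower number from compound 1 to compound 4 (0.87 log units; beyond the scatter); a 2.6-fold lower number from compound 2 to compound 4 (0.41 log units; beyond the scatter)), so the amine at this one place spans a wider range than the earlier compounds showed. A smaller ring goes with a lower number against both six-membered rings, yet the heavy-atom count alone does not settle the matter: compound 1 goes against any such reading, since its open diethylamino group has the same heavy-atom count as the group in compound 4 and still gives the larger number. No measured evidence is available to explain why the group in compound 4 stands apart.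

The compounds shown leave open whether the ring size or the position of the ring double bond goes with the lower number, which a saturated pyrrolidin-1-yl or a morpholin-4-yl at the same place would help to separate. Also open, going by these compounds, is whether this order would hold with a longer chain in place of the saturated chain carbon.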